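A few compounds are considered here, and "the series" means these few. Any claim that something is new, unique, unknown or untested is made for them only; others in the source may bear on it.

Compound 1 `Oc1ccc(-c2cc(-c3ccccc3O)cc(-c3cccc(O)c3)n2)cc1`: 5650 nM
Compound 2 `Oc1cccc(-c2cc(-c3ccccc3O)nc(-c3ccccc3O)c2)c1`: 80 nM
Compound 3 `Oc1cccc(-c2cc(-c3ccccc3O)cc(-c3cccc(O)c3)n2)c1`: 130 nM

All three were measured in an ADME assay on HEK293 cells (Homo sapiens) for cytotoxicity, read by CCK-8 assay, with a stated time of 4 days; on this read-out lower numbers stand for stronger inhibition and higher numbers for weaker inhibition. Among them compound 3 holds the second highest number; compound 2 gives 80 nM, which lies within the scatter of the value of compound 3, while compound 1 gives 5650 nM, the furthest away. Going by the values given here, the one step between measured compounds that differ in a single place is a 43-fold lower number from compound 1 to compound 3 (1.64 log units; beyond the scatter).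

Compound 4 `Oc1cccc(-c2cc(-c3cccc(O)c3)nc(-c3cccc(O)c3)c2)c1` differs from compound 3 in one place: 3-hydroxyphenyl in place of 2-hydroxyphenyl on an aromatic carbon. Among the compounds with values here, no measured step covers the exchange of a 2-hydroxyphenyl for a 3-hydroxyphenyl at this place; the large step already seen concerns a different group at a different place in the core and does not bear directly on it. Compound 2 and compound 3, which share the core but differ in where their hydroxyphenyl groups carry the hydroxyl, give values within the scatter of each other. Compound 4 is therefore expected to stay close to compound 3, with an estimated step of a 1.2-fold lower number from compound 3 to compound 4 (0.07 log units; within the scatter) that is not beyond the scatter. The estimate for compound 4 in this assay is 110 nM, in the range 40 nM to 320 nM.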

Compound 4, half-maximal inhibitory concentration: 740 nM
For compound 4 the middle estimate is 6.7-fold (0.83 log units) below the measured one; the whole stated range lies below it.
By their numbers in this assay, from the lowest: compounds 2 and 3 (each within the scatter of the next); then compound 4; then compound 1.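

Exchanging 2-hydroxyphenyl for 3-hydroxyphenyl opposite the ring nitrogen gives a 5.7-fold higher number from compound 3 to compound 4 (0.76 log units; beyond the scatter) in this assay, so the number at this place depends on where the hydroxyl sits on the ring, even though the two groups have the same atoms. Until now, such a dependence had been seen only at another place on the core, with a 43-fold lower number from compound 1 to compound 3 (1.64 log units; beyond the scatter) for 3-hydroxyphenyl in place of 4-hydroxyphenyl. Nothing available explains why the number rises at this place.

From the compounds shown here alone, it remains open how a 4-hydroxyphenyl, a plain phenyl or a 2-methoxyphenyl opposite the ring nitrogen would compare with the 2-hydroxyphenyl of compound 3. Also open, going by these compounds, is whether this exchange would give a step of similar size with other groups elsewhere on the core.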